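The source may hold more compounds than are shown below. What is called first, only, known or untested is meant among the compounds shown, and "the series" means these compounds.

Within the data shown here, in a functional assay on HT-29 cells (Homo sapiens) for antiproliferative activity, read by sulforhodamine B assay, with a stated time of 48 h (a lower number here means a stronger inhibitor, a higher number a weaker inhibitor), compound 2 (`CCN1CCN(c2ccc(S(=O)(=O)Oc3cccc(OC)c3)cc2)C1=O`) gives 22000 nM, the only true number available so far. Compound 1 (`CN1CCN(c2ccc(S(=O)(=O)Oc3cccc(F)c3)cc2)C1=O`) gives > 100000 nM, which is a limit of the assay and not a number. With so little data, compound 2 can be placed only loosely. The next compound, compound 3 (`CCN1CCN(c2ccc(S(=O)(=O)Oc3cccc(F)c3)cc2)C1=O`), puts fluoro in place of methoxy on an aromatic carbon, turning 3-methoxyphenyl into 3-fluorophenyl: fluoro in place of methoxy on an aromatic carbon. Among the measured compounds shown here, no measured pair shows this change on its own, so the expectation is a judgement. Compound 1 also carries the 3-fluorophenyl group and reads > 100000 nM, so a modest weakening in this assay seems more likely than a gain. The expected change is a 2.0-fold higher number from compound 2 to compound 3 (0.31 log units; beyond the scatter). For compound 3 the estimate is 45000 nM, with an expected range from 15000 nM to 100000 nM.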

Compound 3, half-maximal inhibitory concentration: > 100000 nM
Compound 3 gave a limit, no number; the forecaster's own chance of this, stated with the estimate: 35%; middle value at least 2.2-fold (0.34 log units) away from the limit.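

In this assay, replacing 3-methoxyphenyl with 3-fluorophenyl gives an at least 4.5-fold higher number from compound 2 to compound 3 (0.65 log units; beyond the scatter). At this place on the aromatic ring, then, methoxy gives a measurable reading and fluoro does not, something compound 1 alone could not show without a methoxy partner. The reading for compound 3 is a limit of the assay and not a number, so this step gives only a minimum size: the limit of > 100000 nM in this assay, at which 2 of the 3 values shown sit. The step from compound 1 to compound 3 cannot be read, as both ends are limits.

On these data alone, it remains open whether ethoxy, hydroxy or an amine at this place would read lower or higher than compound 2. Also open, as far as these compounds go, is how much of the reading of compound 2 depends on its ethyl group, with methoxy held in place.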